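A 4-hydroxyphenyl swap on compound 2

The compounds below may be only part of what the source reports. "The series", "measured", "known", "first", "only" and "open" are said of these compounds alone.

In a functional assay on DU-145 cells (Homo sapiens) for inhibition, read by trypan blue exclusion, with a stated time of 96 h (a higher number here means a weaker inhibitor of growth, a lower number a stronger inhibitor of growth), compound 1 (`O=C(/C(=C\c1cc(Cl)cc(Cl)c1Cl)S(=O)(=O)Cc1ccc(Cl)cc1)c1ccc(Br)cc1`) gives 1000 nM and compound 2 (`Cc1cc(C)cc(/C=C(\C(=O)c2ccc(Br)cc2)S(=O)(=O)Cc2ccc(F)cc2)c1`) gives 10000 nM as the concentration for half-maximal growth inhibition. Compound 2 therefore holds the higher of the two numbers, making it the weaker inhibitor of this pair, and the gap to compound 1 lies beyond the scatter. The two compounds differ in more than one place, so their gap cannot be assigned to any single group.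

Compound 3 (`O=C(/C(=C\c1ccc(O)cc1)S(=O)(=O)Cc1ccc(F)cc1)c1ccc(Br)cc1`) has not yet been measured. It differs from compound 2 in one place, on a double-bonded chain carbon bound to a double-bonded chain carbon, where 4-hydroxyphenyl takes the place of 3,5-dimethylphenyl: 4-hydroxyphenyl in place of 3,5-dimethylphenyl on a double-bonded chain carbon bound to a double-bonded chain carbon and nothing else changes. Among the compounds with values here, no measured pair isolates this swap, so any forecast is loose. A modest move to a lower number is expected, and the estimated change is a 2.5-fold lower number from compound 2 to compound 3 (0.40 log units; beyond the scatter) in this assay with wide uncertainty. This expectation rests on compound 1 at 1000 nM and compound 2 at 10000 nM as the only measured reference points. Compound 3 is expected at 4000 nM with 1000 nM to 15000 nM as the estimated range.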

Compound 3, concentration for 50% growth inhibition: 10000 nM
Estimate against measurement, compound 3: 2.5-fold (0.40 log units) below; measured number inside the range.
By their numbers in this assay, from the lowest: compound 1; then compounds 2 and 3 (each within the scatter of the next).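

In this assay, within the data shown here, the step of no change at the digits printed from compound 2 to compound 3 (within the scatter) is the first single-place comparison, and it isolates the ring on a double-bonded chain carbon bound to a double-bonded chain carbon. Exchanging 3,5-dimethylphenyl for 4-hydroxyphenyl at this place brings in 1 hydrogen-bond donor and 1 hydrogen-bond acceptor where the departing group has 0 of each, yet this pair is not separated in the assay, so these two ring substitution patterns cannot be told apart here. No measurement shown here accounts for this result.

As far as these compounds go, whether any group at this place can move the number remains open: a 4-aminophenyl, a 4-carboxyphenyl or a 4-methoxyphenyl ring on the same core might or might not read like this pair. One step also cannot show whether the ring at this place contributes to the value of compound 1 at 1000 nM, as that compound still has no single-place partner among those shown.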